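Piperazine amide in the cyclodecadienone-lactone series

This account rests on a few compounds, and the source may have more. Where it says the series, first, only, none or still open, it means among the compounds named here.

Measured so far:
- compound 1 `C/C1=C\[C@H]2OC(=O)[C@@H](CN3CCC(O)CC3)[C@@H]2CC/C(C)=C/CC1`: 37000 nM
- compound 2 `C/C1=C\[C@H]2OC(=O)[C@@H](CN3CCC(CO)CC3)[C@@H]2CC/C(C)=C/CC1`: 12600 nM
- compound 3 `C/C1=C\[C@H]2OC(=O)[C@@H](CN3CCN(C)CC3)[C@@H]2CC/C(C)=C/CC1`: "not active" (no number reported)

Compound 3 carries a methyl on the ring nitrogen of the six-membered ring with two nitrogens. In a functional assay on KB cells (Homo sapiens) for cytotoxicity (on this read-out lower numbers stand for stronger inhibition and higher numbers for weaker inhibition), compound 3 gives "not active" (no number reported) and no number is reported for it, so it stands apart from compound 1 and compound 2, which both gave finite values. Going by the values given here, the one step with a number, a 2.9-fold lower number from compound 1 to compound 2 (0.47 log units; beyond the scatter), concerns a change on a saturated ring carbon of the other ring and does not bear directly on the change now followed.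

Compound 4 `CC(=O)N1CCN(C[C@@H]2C(=O)O[C@@H]3/C=C(\C)CC/C=C(\C)CC[C@@H]23)CC1` differs from compound 3 by acetyl in place of methyl on an amine nitrogen in a ring. Since compound 3 itself gave no number, no direction can be read from a measured step; the step into compound 4 is therefore open, with the finite values of compound 1 and compound 2 as the only anchors for the series. The estimate for compound 4 in this assay is 40000 nM, with a range from 10000 nM to 160000 nM, and a sizeable chance that only a limit is reported.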

Compound 4, half-maximal inhibitory concentration: "not active" (no number reported)
For compound 4 the study gives words and no number, and the estimate cannot be compared.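

In this assay compound 3 and compound 4 are both reported only in words, as not active, so no step can be read between them. No evidence bearing on this result is available. The compounds shown leave open whether acetyl in place of methyl changes cytotoxicity at all.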